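Ethyl on the aryl amide of a diazabicyclic nicotinamide

The compounds below may be only part of what the source reports. "The series", "measured", "known", "first", "only" and "open" are said of these compounds alone.

Compound 1 `O=C(Nc1ccc(F)cc1F)c1cncc(N2CC3CC(C2)N3)c1`: 0.051 nM
Compound 2 `O=C(Nc1ccccc1F)c1cncc(N2CC3CC(C2)N3)c1`: 0.315 nM
Compound 3 `O=C(Nc1ccccc1)c1cncc(N2CC3CC(C2)N3)c1`: 1.1 nM

Three compounds share a core and differ only in the aryl group on the amide nitrogen, and all were measured in an assay on membranes from Cerebral cortex for displacement of a labelled ligand from Neuronal acetylcholine receptor; alpha4/beta2 (Rattus norvegicus); on this read-out lower numbers stand for stronger inhibition and higher numbers for weaker inhibition. Compound 3 `O=C(Nc1ccccc1)c1cncc(N2CC3CC(C2)N3)c1` gives 1.1 nM and stands at the highest number of the three: compound 2 is nearest, a 3.5-fold higher number from compound 2 to compound 3 (0.54 log units; beyond the scatter), and compound 1 furthest, a 22-fold higher number from compound 1 to compound 3 (1.33 log units; beyond the scatter). The step from compound 1 to compound 2 is a 6.2-fold higher number from compound 1 to compound 2 (0.79 log units; beyond the scatter).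

Compound 4 `CCc1cccc(NC(=O)c2cncc(N3CC4CC(C3)N4)c2)c1` is not yet measured. It differs from compound 3 by ethyl in place of hydrogen on an aromatic carbon. The measured steps all concern fluoro on an aromatic carbon, and each time a fluoro left the number rose. Ethyl at this place is a different change, with no measured step bearing directly on it; those steps only show that the aryl group matters. A modest step in either direction, or none beyond the scatter, is plausible. Compound 4 is therefore expected near compound 3, with the estimated step of a 1.1-fold lower number from compound 3 to compound 4 (0.04 log units; within the scatter), giving an estimate of 1 nM in this assay, within 0.25 nM to 4 nM.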

Compound 4, inhibition constant: 1.3 nM
Estimate against measurement, compound 4: 1.3-fold (0.11 log units) below, within the range that was stated.
By their numbers in this assay, from the lowest: compound 1; then compound 2; then compounds 3 and 4 (each within the scatter of the next).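

In this assay, going by these compounds alone, the first change on the aromatic carbon meta to a large group leaves the number where it was: ethyl in place of hydrogen gives a step within the scatter (a 1.2-fold higher number from compound 3 to compound 4 (0.07 log units; within the scatter)), so this place accepts a group of 2 carbon atoms with no measurable cost or gain, whereas each fluoro step had been beyond the scatter. Compound 4 accordingly stays apart from the fluorinated compounds, as the steps show (a 4.1-fold higher number from compound 2 to compound 4 (0.62 log units; beyond the scatter); a 25-fold higher number from compound 1 to compound 4 (1.41 log units; beyond the scatter)). Nothing available explains why the ethyl group has so little effect here.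

The compounds shown leave open whether a longer chain such as propyl, or an amine or a carboxylic acid, would be accepted at this place as ethyl is. They also leave open whether ethyl would behave the same way on the 2,4-difluorophenyl group of compound 1.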